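The source may hold more compounds than are shown below. What is called first, only, known or untested is meant among the compounds shown, and "the series" means these compounds.

Measured in an ADME assay on BE(2)-C cells (Homo sapiens) for cytotoxicity, read by MTT assay, with a stated time of 20 h; on this read-out lower numbers stand for higher toxicity in this test and higher numbers for lower toxicity in this test:

compound 1 `CN1CCC(CNC(=O)C2CCN(C(=O)c3cc4ccccc4n3Cc3ccc(Cl)cc3)CC2)CC1`: > 50000 nM, a limit
compound 2 `Cn1ccc(CNC(=O)C2CCN(C(=O)c3cc4ccccc4n3Cc3ccc(Cl)cc3)CC2)n1`: > 100000 nM, a limit
compound 3 `Cn1cnc(CNC(=O)C2CCN(C(=O)c3cc4ccccc4n3Cc3ccc(Cl)cc3)CC2)c1`: > 50000 nM, a limit

None of the three compounds has a numerical reading. The series stands at the limit of > 50000 nM in this assay, at which 2 of the 3 values shown sit, and at the limit of > 100000 nM in this assay, at which 1 of the 3 values shown sits. Compound 3 has only a limit, > 50000 nM, so it offers no exact starting point.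

The account now turns to compound 4 `O=C(NCC1COc2cnccc21)C1CCN(C(=O)c2cc3ccccc3n2Cc2ccc(Cl)cc2)CC1`, which differs from compound 3 on a saturated chain carbon bound to an amide-type nitrogen: a group of 9 heavy atoms (7 carbon, 1 nitrogen, 1 oxygen; one five-membered non-aromatic ring with 1 hetero atom, one six-membered aromatic ring with 1 hetero atom) in place of a group of 6 heavy atoms (4 carbon, 2 nitrogen; one five-membered aromatic ring with 2 hetero atoms), on a saturated chain carbon bound to an amide-type nitrogen.

The measured steps that bear on this change are those made at the same place: a step that the two limits leave unreadable from compound 1 to compound 2, a step that the two limits leave unreadable from compound 1 to compound 3 and a step that the two limits leave unreadable from compound 2 to compound 3. None of them has a readable size. They do show that all three groups tried at this place left the reading at a limit, though they give no size or direction to carry over. No step beyond the usual scatter is therefore expected in this assay, and no direction is predicted. The expected change is a step that the limit leaves unreadable from compound 3 to compound 4. A report of only a limit is considered the likely outcome for the new compound. Compound 4 is estimated at 60000 nM, with an expected range from 25000 nM to 120000 nM.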

Compound 4, half-maximal cytotoxic concentration: 75800 nM
The estimate for compound 4 lay 1.3-fold (0.10 log units) below the measured number; low and high end bracket the measured number.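

In this assay compound 4 gives 75800 nM, the first numerical reading among the groups shown on a saturated chain carbon bound to an amide-type nitrogen. At this place, 1-methylpiperidin-4-yl, 1-methyl-1H-pyrazol-3-yl and 1-methyl-1H-imidazol-4-yl each left only a limit. Going by these compounds alone, the one step that can be read is an at least 1.3-fold lower number from compound 2 to compound 4 (0.12 log units; that floor lies within the scatter), and it is a floor rather than a measured size, so it does not establish a change beyond the usual scatter. The steps to compound 4 from compound 1 and from compound 3 cannot be read, and the other readings remain limits: the limit of > 50000 nM in this assay, at which 2 of the 4 values shown sit.

The compounds shown leave open where the true readings of compound 1, compound 2 and compound 3 lie relative to compound 4, so no order among the four groups can be given. They also leave open how a carboxylic acid or a primary amine at this place would read in this assay, now that compound 4 offers an exact number for comparison.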